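Ester variation on the hydroxyethyl side chain: compound 3 to compound 4

The source may hold more compounds than are shown below. What is called first, only, known or untested is meant among the compounds shown, and "the series" means these compounds.

Measured so far in an ADME assay on HepG2 2.2.15 cells (Homo sapiens) for cytotoxicity; a lower number here means that less compound is tolerated, a higher number that more compound is tolerated:
compound 1, `Cn1c(=O)c(CCO)c(-c2ccccc2Cl)c2cc(Cl)ccc21`, gives 34000 nM
compound 2, `O=c1c(CCO)c(-c2ccccc2Cl)c2cc(Cl)ccc2n1-c1ccccc1`, gives 26000 nM
compound 3, `O=C(CCC1CCCCC1)OCCc1c(-c2ccccc2Cl)c2cc(Cl)ccc2[nH]c1=O`, gives 160000 nM

In this assay compound 3 stands highest of the three numbers, beyond the scatter from both compound 1 and compound 2. Within the data shown here, the only step between compounds differing in one place, a 1.3-fold lower number from compound 1 to compound 2 (0.12 log units; within the scatter), concerns a phenyl in place of methyl on the aromatic nitrogen and not the ester, so it does not bear on the present change.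

Compound 4, `COc1ccc(/C=C/C(=O)OCCc2c(-c3ccccc3Cl)c3cc(Cl)ccc3[nH]c2=O)cc1OC`, differs from compound 3 by 2-(3,4-dimethoxyphenyl)ethenyl in place of 2-cyclohexylethyl on a carbonyl carbon. Among the measured compounds shown here, no measured pair tests a change within the ester, so the expectation rests on compound 3 alone: a modest step, a 1.6-fold lower number from compound 3 to compound 4 (0.20 log units; within the scatter), toward a somewhat lower number is expected. Compound 4 is estimated at 100000 nM, with a range from 35000 nM to 300000 nM.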

Compound 4, half-maximal cytotoxic concentration: > 1200000 nM
Compound 4 was reported as a limit (the forecaster's own chance of this, stated with the estimate: 15%); at least 12-fold (1.07 log units) between middle value and limit.
By their numbers in this assay, from the lowest: compounds 2 and 1 (each within the scatter of the next); then compound 3. At a limit, above all of these: compound 4.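

On the carbonyl carbon of the ester, 2-(3,4-dimethoxyphenyl)ethenyl in place of 2-cyclohexylethyl gives an at least 7.5-fold higher number from compound 3 to compound 4 (0.87 log units; beyond the scatter) in this assay. Among these compounds, this is the first one-place step to lie beyond the scatter, so the ester side chain can move this read-out. In this assay compound 4 gives > 1200000 nM, which is a limit.

A single pair does not separate the contributions of the aromatic ring, the methoxy groups and the double bond. On these data alone, whether an ester carrying an amine or a carboxylic acid would behave like compound 4 remains open.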